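The source may report more compounds than this note shows. Statements on the series, on what has been measured and on what is new or still open speak of the compounds shown alone.

Measured so far in an in vivo ADME assay on the whole organism (strain Sprague-Dawley) for metabolic stability, with Rattus norvegicus as the target; a lower number here means that the compound disappears faster, a higher number that the compound lasts longer:
Compound 1 `CC(C)[C@@H]1NC[C@@H](C)Oc2ccccc2CCCNC(=O)[C@@H](Cc2ccc(F)cc2)NC(=O)[C@@H](C)N(C)C1=O` gives 34 h
Compound 2 `CCC[C@@H]1NC[C@@H](C)Oc2ccccc2CCCNC(=O)[C@@H](Cc2ccc(F)cc2)NC(=O)[C@@H](C)N(C)C1=O` gives 29 h
Compound 3 `C[C@@H]1CN[C@@H](C2CCCCC2)C(=O)N(C)[C@H](C)C(=O)N[C@H](Cc2ccc(F)cc2)C(=O)NCCCc2ccccc2O1` gives 74 h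

Compound 3 has the highest of these three numbers, and its gaps to both others lie beyond the scatter. Compound 4 `CC[C@H](C)[C@@H]1NC[C@@H](C)Oc2ccccc2CCCNC(=O)[C@@H](Cc2ccc(F)cc2)NC(=O)[C@@H](C)N(C)C1=O` has not yet been measured. It has sec-butyl in place of cyclohexyl on a saturated ring carbon and otherwise keeps the core of compound 3.

All three measured steps change this same carbon. Replacing isopropyl with cyclohexyl gives a 2.2-fold higher number from compound 1 to compound 3 (0.34 log units; beyond the scatter) and replacing propyl with cyclohexyl gives a 2.6-fold higher number from compound 2 to compound 3 (0.41 log units; beyond the scatter), both modest. The two open chains barely separate, with a 1.2-fold lower number from compound 1 to compound 2 (0.07 log units; within the scatter) in this assay. Sec-butyl also has no ring, so compound 4 is expected to fall back towards compound 1 and compound 2, though the data hold no sec-butyl example to confirm this. The expected change is a 1.9-fold lower number from compound 3 to compound 4 (0.27 log units; within the scatter), a modest drop. For compound 4 the estimated half-life is 40 h, with an expected range from 23 h to 70 h.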

Compound 4, half-life: 44 h
The estimate for compound 4 lay 1.1-fold (0.04 log units) below the measured number; low and high end bracket the measured number.
By their numbers in this assay, from the lowest: compounds 2, 1, 4 and 3 (each within the scatter of the next, the first and the last beyond it).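

In this assay, sec-butyl in place of cyclohexyl gives a 1.7-fold lower number from compound 3 to compound 4 (0.23 log units; within the scatter), so this open chain, unlike isopropyl and propyl, cannot be separated from cyclohexyl at this ring carbon. It also cannot be separated from the other two open chains, with a 1.5-fold higher number from compound 2 to compound 4 (0.18 log units; within the scatter) and a 1.3-fold higher number from compound 1 to compound 4 (0.11 log units; within the scatter), so the extra methyl on the chain makes no readable difference, and the clear gap between a ring and an open chain now rests only on isopropyl and propyl. No measurement shown here explains these numbers.

Going by these compounds, it remains open whether the other configuration of the sec-butyl stereocentre would read the same. Also open, on these data alone, is how a smaller ring such as cyclopentyl, a phenyl ring or a chain ending in an amine would behave at this carbon.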